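Working notes: hydroxy for methyl in this series

The source may report more compounds than this note shows. Statements on the series, on what has been measured and on what is new or still open speak of the compounds shown alone.

Measured so far in a functional assay on NCI-H460 cells (Homo sapiens) for cytotoxicity, read by MTT assay, with a stated time of 72 h; a lower number here means a stronger inhibitor of growth, a higher number a weaker inhibitor of growth
- compound 1 `N#C/C(=C/c1ccc2ccccc2c1)C(=O)c1ccc[nH]1` gives < 10000 nM
- compound 2 `Cc1ccc(/C=C(/C#N)C(=O)c2ccc[nH]2)cc1` gives 11000 nM
- compound 3 `N#C/C(=C/c1ccc(Cl)c(Cl)c1)C(=O)c1ccc[nH]1` gives < 10000 nM

Among the compounds with values here, compound 2 at 11000 nM is the only actual number in the set. Compound 1 at < 10000 nM stands at a limit of the assay and not at a number. Compound 3 at < 10000 nM is likewise a limit and not a number. Within the data shown here, that leaves the limit of < 10000 nM in this assay, at which 2 of the 3 values shown sit, as the main feature of the data, and no two measured compounds differ in one place only.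

The next compound is compound 4 `N#C/C(=C/c1ccc(O)cc1)C(=O)c1ccc[nH]1` with hydroxy in place of methyl on an aromatic carbon as its change from compound 2, hydroxy in place of methyl on an aromatic carbon. With compound 2 at 11000 nM as the only anchor, no step beyond the scatter is expected in this assay and no direction is favoured. The estimated move a 1.2-fold lower number from compound 2 to compound 4 (0.09 log units; within the scatter) stays within the scatter. For compound 4 the estimate is 9000 nM with an expected range of 3000 nM to 30000 nM in this assay.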

Compound 4, concentration for 50% growth inhibition: < 10000 nM
Compound 4: no number, only a limit; the forecaster's own chance of this, stated with the estimate: 50%; the middle value is on the limit's open side.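

Hydroxy in place of methyl on an aromatic carbon, para to a large group, gives the first one-place step in the series in this assay: an at least 1.1-fold lower number from compound 2 to compound 4 (0.04 log units; that floor lies within the scatter). Compound 4 gives < 10000 nM, which is a limit of the assay and not a number, so this step has a floor but no measured size. At this position the change therefore shows no rise in the number, but the data read mainly as a crowding at one limit and not as a trend: the limit of < 10000 nM in this assay, at which 3 of the 4 values shown sit.

As far as these compounds go, the steps among the compounds that sit at the limit cannot be read, and the distance of compound 4 from the limit stays open. Also open, from the compounds shown here alone, is how an amine, a carboxylic acid or a longer chain at this position would read in this assay.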